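Cytotoxicity of a Deoxyuridine Bearing a Hex-1-yn-1-yl Group

A few compounds are considered here, and "the series" means these few. Any claim that something is new, unique, unknown or untested is made for them only; others in the source may bear on it.

Measured so far:
Compound 1 `O=C1O/C(=C\Cn2ccc(=O)[nH]c2=O)C(OCc2ccccc2)=C1OCc1ccccc1`: 12900 nM
Compound 2 `N#Cc1cn([C@H]2C[C@H](O)[C@@H](CO)O2)c(=O)[nH]c1=O`: > 200000 nM (a limit, not a number)
Compound 3 `COC1=C(OC)C(CCn2cnc3c(N)ncnc32)(/[S+]=C/C(NC(C)=O)C(=O)O)OC1=O`: > 200000 nM (a limit, not a number)

In an ADME assay on L1210/0 cells (Mus musculus) for cytotoxicity, with a stated time of 48 h (on this read-out higher numbers stand for weaker inhibition and lower numbers for stronger inhibition), compound 1 gives 12900 nM. For compound 2 only the limit > 200000 nM is known, so no number marks where it stands; it sits at the limit of > 200000 nM in this assay, at which 2 of the 3 values shown sit, together with compound 3. Compound 4 `CCCCC#Cc1cn([C@H]2C[C@H](O)[C@@H](CO)O2)c(=O)[nH]c1=O` differs from compound 2 in one place: hex-1-yn-1-yl in place of cyano on an aromatic carbon. Among the measured compounds shown here, with no measured pair to lean on, the step from compound 2 to compound 4 is expected to reach a measurable number, toward stronger inhibition, as an at least 4.0-fold lower number from compound 2 to compound 4 (0.60 log units; beyond the scatter). Compound 4 is estimated at 50000 nM, between 10000 nM and 200000 nM.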

Compound 4, half-maximal inhibitory concentration: > 200000 nM
Compound 4: no number, only a limit (the forecaster's own chance of this, stated with the estimate: 35%); middle value at least 4.0-fold (0.60 log units) away from the limit.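

Compound 2 and compound 4 both give only a limit, not a number, so no step between them can be read: the limit of > 200000 nM in this assay, at which 3 of the 4 values shown sit.

On these data alone, whether hex-1-yn-1-yl in place of cyano changes the result at all in this assay stays open.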